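The source may report more compounds than this note shows. Statements on the series, on what has been measured and on what is new or still open speak of the compounds shown alone.

Compound 1, `COc1ccc(/C=C2\CCC/C(=C\c3cccc(OC)c3OC)C2=O)cc1`, gives 16300 nM.
Compound 2, `COc1cccc(/C=C2\CCC/C(=C\c3ccc(Cl)cc3Cl)C2=O)c1OC`, gives only a limit, > 20000 nM.
Compound 3, `COc1ccc(/C=C2\CCC/C(=C\c3ccc(Cl)cc3)C2=O)cc1OC`, gives 4800 nM.

These three share one core and differ only in the aryl groups hung on it. In a functional assay on HT-1080 cells (Homo sapiens) for cytotoxicity, read by MTT assay, with a stated time of 72 h (on this read-out lower numbers stand for stronger inhibition and higher numbers for weaker inhibition), compound 3 stands lowest of the two numbers that were obtained; compound 1 is its nearest neighbour, and the gap from compound 3 up to compound 1 lies beyond the usual scatter. The value of compound 2 is a limit, not a number, so compound 2 sits at the limit of > 20000 nM in this assay, at which 1 of the 3 values shown sits.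

Compound 4, `COc1ccc(/C=C2\CCC/C(=C\c3cc(Cl)cc(Cl)c3)C2=O)cc1OC`, has not yet been measured. It differs from compound 3 in one place: 3,5-dichlorophenyl in place of 4-chlorophenyl on a double-bonded chain carbon bound to a double-bonded ring carbon.

Among the measured compounds shown here, only one measured step bears on this change. It is an at least 1.2-fold higher number from compound 1 to compound 2 (0.08 log units; that floor lies within the scatter), where a second chlorine also entered an aryl group, and it ended at a limit rather than a number, so its true size is not known. That gives a weak hint that adding a chlorine does not lower the number here, and no hint of a large move in either direction. Compound 4 is therefore expected to sit close to compound 3 or somewhat higher, an estimated step of a 1.5-fold higher number from compound 3 to compound 4 (0.16 log units; within the scatter). The estimate for compound 4 is 7000 nM, in a range from 2500 nM to 20000 nM.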

Compound 4, half-maximal inhibitory concentration: 3000 nM
Estimate against measurement, compound 4: 2.3-fold (0.37 log units) above; low and high end bracket the measured number.
By their numbers in this assay, from the lowest: compounds 4 and 3 (each within the scatter of the next); then compound 1. At a limit, above all of these: compound 2.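

In this assay putting 3,5-dichlorophenyl in place of 4-chlorophenyl gives a 1.6-fold lower number from compound 3 to compound 4 (0.20 log units; within the scatter) and so, on this double-bonded chain carbon, the two groups cannot be told apart. This is the first change to a dichlorophenyl group shown here with a real number at both ends: the earlier change to 2,4-dichlorophenyl in compound 2 ended at a limit, so its size could not be read. With the rest of compound 3 held fixed, a second chlorine on this aryl group therefore costs nothing measurable when the group is 3,5-dichlorophenyl, although nothing measured here says why the two groups read alike.

As far as these compounds go, whether the chlorines themselves matter remains open, as does the reading of a plain phenyl group, a 3,5-difluorophenyl group or a phenyl group carrying an amine at this place. Also open, from the compounds shown here alone, is whether 3,5-dichlorophenyl would be tolerated equally well with the other aryl group changed, for example to the 4-methoxyphenyl group of compound 1.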